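Replacing the Charged Ring of Compound 3 with Allyloxy

The compounds below may be only part of what the source reports. "The series", "measured", "known", "first", "only" and "open" are said of these compounds alone.

Compound 1, `O=C(Nc1ccc2nc(NC(=O)C3CCCCC3)sc2c1)c1cccc(F)c1`, gives 0.64 ug/mL in a functional assay on WI-38 VA13 cells (Homo sapiens) for cytotoxicity; a lower number here means that less compound is needed, a higher number that more compound is needed for the effect.
Compound 2, `CCC(C)(C)C(=O)Nc1ccc2nc(NC(=O)C3CCCCC3)sc2c1`, gives 1 ug/mL.
Compound 3, `Cc1[nH][n+](C)c(C)c1C(=O)Nc1ccc2nc(NC(=O)C3CCCCC3)sc2c1`, gives 0.012 ug/mL.

Compound 3 holds the lowest number of the three. The step of a 53-fold lower number from compound 1 to compound 3 (1.73 log units; beyond the scatter) and the step of an 83-fold lower number from compound 2 to compound 3 (1.92 log units; beyond the scatter) both lie well beyond the scatter, so compound 3 stands clearly apart from the other two. Between compound 1 and compound 2 the step of a 1.6-fold higher number from compound 1 to compound 2 (0.19 log units; within the scatter) stays within the scatter, so those two are not distinguishable.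

Compound 4, `C=CCOC(=O)Nc1ccc2nc(NC(=O)C3CCCCC3)sc2c1`, differs from compound 3 by a group of 4 heavy atoms (3 carbon, 1 oxygen; no ring) in place of a group of 8 heavy atoms (6 carbon, 2 nitrogen; one five-membered aromatic ring with 2 hetero atoms), on a carbonyl carbon. Both measured steps into compound 3 bear on this change: each time a group without the five-membered aromatic ring with 2 hetero atoms sat on that carbonyl carbon, the number was far higher, and the aryl and alkyl groups of compound 1 and compound 2 gave similar numbers. The allyloxy group of compound 4 likewise lacks that ring, so a large step upward, of the size seen in those two steps, is expected.

Compound 4 is therefore estimated at 1 ug/mL, with a range from 0.3 ug/mL to 4 ug/mL. This amounts to an expected step of an 83-fold higher number from compound 3 to compound 4 (1.92 log units; beyond the scatter).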

Compound 4, half-maximal effective concentration: 0.58 ug/mL
The estimate for compound 4 lay 1.7-fold (0.24 log units) above the measured number; measured number inside the range.
By their numbers in this assay, from the lowest: compound 3; then compounds 4, 1 and 2 (each within the scatter of the next).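

In this assay, the allyloxy group on a carbonyl carbon whose other neighbours are amide-type nitrogen takes the number far away from that of the charged five-membered ring (a 48-fold higher number from compound 3 to compound 4 (1.68 log units; beyond the scatter)). Its number cannot be told apart from those of the 1,1-dimethylpropyl group (a 1.7-fold lower number from compound 2 to compound 4 (0.24 log units; within the scatter)) or the 3-fluorophenyl group (a 1.1-fold lower number from compound 1 to compound 4 (0.04 log units; within the scatter)), so three groups that differ in ring content and in the atom bonded to the carbonyl carbon all fall within the scatter of one another, and compound 3 alone goes against this pattern. Nothing measured here explains why compound 3 stands apart from the other three compounds, and the size of this gap therefore remains without a stated cause.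

The group that leaves in going to compound 4 differs from allyloxy in both its aromatic ring and its net charge of +1, so the compounds shown cannot say which of the two goes with the low number of compound 3. The uncharged form of the same pyrazole ring, or a quaternary ammonium group without any ring, on that carbonyl carbon would pull these two features apart.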